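Dropping the Second Ring: Estimating a Chlorophenyl Sulfonamide

The source may hold more compounds than are shown below. What is called first, only, known or untested is meant among the compounds shown, and "the series" means these compounds.

Compound 1 `COc1ccccc1-c1cccc(S(=O)(=O)N2CCC(N3CCC(C)CC3)CC2)c1`: 21 nM
Compound 2 `CC1CCN(C2CCN(S(=O)(=O)c3cccc(-c4ccc(Cl)cc4)c3)CC2)CC1`: 15 nM
Compound 3 `CC1CCN(C2CCN(S(=O)(=O)c3ccc(C#N)cc3)CC2)CC1`: 2800 nM

In a functional assay on DLD-1 cells (Homo sapiens) for antiproliferative activity, read by CellTiter-Glo, with a stated time of 72 h (on this read-out higher numbers stand for weaker inhibition and lower numbers for stronger inhibition), compound 3 stands highest of the three measured numbers; compound 1 and compound 2 both sit far lower, and each gap lies beyond the scatter. Compound 4 `CC1CCN(C2CCN(S(=O)(=O)c3cccc(Cl)c3)CC2)CC1` differs from compound 3 in one place: 3-chlorophenyl in place of 4-cyanophenyl on a sulfonyl sulfur. For the measured compounds named here, the only measured step, a 1.4-fold lower number from compound 1 to compound 2 (0.15 log units; within the scatter), exchanges one substituted phenyl for another and lies within the scatter, so it does not speak directly to this change. Compound 4, like compound 3, carries neither 4-chlorophenyl nor 2-methoxyphenyl, whereas compounds 1 and 2 do. A modest fall in the number is therefore expected, a 1.9-fold lower number from compound 3 to compound 4 (0.27 log units; within the scatter). Compound 4 is estimated at 1500 nM, ranging from 300 nM to 8000 nM.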

Compound 4, half-maximal inhibitory concentration: > 5000 nM
Compound 4: a limit, no number (the forecaster's own chance of this, stated with the estimate: 5%); at least 3.3-fold (0.52 log units) between middle value and limit.
By their numbers in this assay, from the lowest: compounds 2 and 1 (each within the scatter of the next); then compound 3. At a limit, above all of these: compound 4.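

In this assay compound 4 gives a limit, not a number: the limit of > 5000 nM in this assay, at which 1 of the 4 values shown sits. Putting chloro where the larger aryl groups stood gives an at least 330-fold higher number from compound 2 to compound 4 (2.52 log units; beyond the scatter) and an at least 230-fold higher number from compound 1 to compound 4 (2.37 log units; beyond the scatter), so on this aromatic carbon a second phenyl ring, with either substituent, goes with the low numbers. From the compounds shown here alone, changing the group on the sulfonyl sulfur gives an at least 1.7-fold higher number from compound 3 to compound 4 (0.25 log units; that floor lies within the scatter); that floor lies within the scatter, so the true size of this step stays unknown. Still open, going by these compounds, is whether an amine or a pyridine ring in place of the chloro would bring the number back down.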